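A Second Methoxy Group on the Weaker Boron Core

A few compounds are considered here, and "the series" means these few. Any claim that something is new, unique, unknown or untested is made for them only; others in the source may bear on it.

Compound 1, `O=C(CCc1cccc2c1B(O)OC2)Nc1cccc(-c2ccccc2)c1`, gives 890 nM in a functional assay on HCT-116 cells (Homo sapiens) for antiproliferative activity, read by MTT assay, with a stated time of 72 h; on this read-out lower numbers stand for stronger inhibition and higher numbers for weaker inhibition.
Compound 2, `COc1ccc(-c2cccc(NC(=O)CCc3cccc4c3B(O)OC4)c2)cc1`, gives 160 nM in this assay.
Compound 3, `COc1cccc(-c2cccc(NC(=O)CCc3ccc4c(c3)B(O)OC4)c2)c1`, gives 21000 nM in this assay.

Compound 2 differs from compound 1 by methoxy in place of hydrogen on an aromatic carbon, and this change brought a 5.6-fold lower number from compound 1 to compound 2 (0.75 log units; beyond the scatter). Compound 3 is built on a different core; how the core of compound 1 and the core of compound 3 differ is not broken down here, and compound 3 stands far weaker than both of the others.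

Compound 4, `COc1cc(OC)cc(-c2cccc(NC(=O)CCc3ccc4c(c3)B(O)OC4)c2)c1`, has not been measured. It differs from compound 3 by methoxy in place of hydrogen on an aromatic carbon. This is the same kind of change as that from compound 1 to compound 2, but not the same: in compound 4 the new methoxy enters meta to a large group and meta to a methoxy group, whereas in compound 2 it sits para to a large group. Going by the values given here, the step in this assay is expected to be a 2.1-fold lower number from compound 3 to compound 4 (0.32 log units; beyond the scatter), smaller than the earlier one, as the place is different and the core is the one that gives compound 3 its 21000 nM. Compound 4 is therefore estimated at 10000 nM, expected to fall between 3000 nM and 40000 nM.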

Compound 4, half-maximal inhibitory concentration: 3700 nM
Estimate against measurement, compound 4: 2.7-fold (0.43 log units) above; the range from low to high includes it.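

On the core of compound 3, the added methoxy group gives a 5.7-fold lower number from compound 3 to compound 4 (0.75 log units; beyond the scatter) in this assay and this matches the size of the step seen on the core of compound 1: the same change on two cores in this assay, a 5.6-fold lower number (0.75 log units; beyond the scatter) from compound 1 to compound 2 and a 5.7-fold lower number (0.75 log units; beyond the scatter) from compound 3 to compound 4, 1.0-fold (0.01 log units) apart, within the scatter of two such steps

For these two pairs, then, the size of the step did not depend on the core, even though the new methoxy sits para to a large group in compound 2 and meta to a large group and meta to a methoxy group in compound 4. This rests on just two pairs, so it is no general rule for other cores or other places on the ring, and it does not say why the two steps match.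

The compounds shown leave open how the two cores compare when everything else is held equal. Also open, on these data alone, is whether an amine or a carboxylic acid in place of the new methoxy, or a longer chain in place of the one joining the amide to the core, would bring a step of similar size on both cores.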